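From methoxycarbonyl to benzyloxycarbonyl on compound 2

The compounds below may be only part of what the source reports. "The series", "measured", "known", "first", "only" and "open" are said of these compounds alone.

Going by the values given here, in a functional assay on MKN-28 cells (Homo sapiens) for cytotoxicity, read by MTT assay (on this read-out higher numbers stand for weaker inhibition and lower numbers for stronger inhibition), compound 2 (`C=C1C(=O)[C@]23C[C@@]1(O)CC[C@H]2[C@@]12C=CC(=O)[C@](C)(C(=O)O1)[C@H]2[C@@H]3C(=O)OC`) gives 39600 nM, the higher of the two numbers so far and so the weaker inhibition. Compound 1 (`C=C1C(=O)[C@]23C[C@@]1(Cl)CC[C@H]2[C@@]12C=CC(=O)[C@](C)(C(=O)O1)[C@H]2[C@@H]3C(=O)OCc1ccccc1`) gives 6800 nM, lower by a margin beyond the scatter.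

Compound 3 (`C=C1C(=O)[C@]23C[C@@]1(O)CC[C@H]2[C@@]12C=CC(=O)[C@](C)(C(=O)O1)[C@H]2[C@@H]3C(=O)OCc1ccccc1`) departs from compound 2 in one place: phenyl in place of hydrogen on a saturated chain carbon bound to an oxygen next to a carbonyl group. This puts phenyl in place of hydrogen on a saturated chain carbon bound to an oxygen next to a carbonyl group, turning methoxycarbonyl into benzyloxycarbonyl. Among the compounds with values here, no measured step isolates this change. Within the data shown here, compound 1 at 6800 nM is the only measured compound with benzyloxycarbonyl, but the two measured compounds differ in more than this one place, so it is a loose guide. A moderate move to a lower number in this assay is expected, estimated as a 2.5-fold lower number from compound 2 to compound 3 (0.39 log units; beyond the scatter). For compound 3 the estimated value is 16000 nM, with an expected range of 6000 nM to 42000 nM.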

Compound 3, half-maximal inhibitory concentration: 2500 nM
Compound 3: middle estimate off by 6.4-fold (0.81 log units), on the high side; the whole stated range lies above it.
By their numbers in this assay, from the lowest: compound 3; then compound 1; then compound 2.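

In this assay, the ester position is strongly responsive: phenyl in place of hydrogen on a saturated chain carbon bound to an oxygen next to a carbonyl group, turning methoxycarbonyl into benzyloxycarbonyl, gives a large step (a 16-fold lower number from compound 2 to compound 3 (1.20 log units; beyond the scatter)). With benzyloxycarbonyl held constant, hydroxy in place of chloro on a saturated ring carbon gives a modest step in the same direction (a 2.7-fold lower number from compound 1 to compound 3 (0.43 log units; beyond the scatter)), so chloro is not what places compound 1 below compound 2 on this read-out. No measurement available here bears on the reason for either step.

Open, from the compounds shown here alone, is whether the phenyl ring itself matters, or whether a cyclohexylmethyl ester, a longer alkyl chain or a free carboxylic acid at this place would give a similar number. Also open, going by these compounds, is whether the chloro and hydroxy groups would compare the same way with methoxycarbonyl in the molecule.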